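One Amine Swap on the Thiocarbonyl Carbon

The source may report more compounds than this note shows. Statements on the series, on what has been measured and on what is new or still open speak of the compounds shown alone.

Measured so far:
compound 1 `O=c1cc(CSC(=S)N2CCCCC2)oc2cc(Cl)ccc12` — in a functional assay on HeLa cells (Homo sapiens) for antiproliferative activity, read by MTT assay, with a stated time of 72 h (a higher number here means a weaker inhibitor, a lower number a stronger inhibitor), compound 1 gives > 25000 nM
compound 2 `O=c1c(Cl)c(CSC(=S)N2CCCC2)oc2ccccc12` — compound 2 gives 700 nM
compound 3 `O=c1c(CSC(=S)N2CCCCC2)coc2ccccc12` — compound 3 gives 2300 nM

The reading for compound 1 is a limit of the assay, not a number (the limit of > 25000 nM in this assay, at which 1 of the 3 values shown sits); compound 1 therefore sits at the weak end of what has been measured, with no exact value. Among the measured compounds shown here, compound 2 and compound 3 give numbers, but neither differs from compound 1 in one place, so no single step can be drawn from them.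

Compound 4 `CC(C)N(C(=S)SCc1cc(=O)c2ccc(Cl)cc2o1)C(C)C` is not yet measured. It differs from compound 1 by diisopropylamino in place of piperidin-1-yl on a thiocarbonyl carbon. For the measured compounds named here, with no step between measured compounds to lean on, no change beyond the usual scatter is expected, and the step that the limit leaves unreadable from compound 1 to compound 4 is estimated to be flat. Compound 4 is thus expected near 30000 nM, within 8000 nM to 100000 nM.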

Compound 4, half-maximal inhibitory concentration: > 30000 nM
Compound 4: a limit, no number (the forecaster's own chance of this, stated with the estimate: 65%); the middle value sits exactly at the limit.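

Compound 1 and compound 4 both read as limits of this assay, not as numbers, and the step between them cannot be read. The compounds shown leave open whether diisopropylamino in place of piperidin-1-yl on a thiocarbonyl carbon changes activity at all.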